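This account rests on a few compounds, and the source may have more. Where it says the series, first, only, none or still open, it means among the compounds named here.

Measured compounds:
compound 1, `Cc1cc(OCCCS(C)(=O)=O)cc(C)c1-c1cccc(COc2ccc(OCC(=O)O)c(F)c2)c1`, gives 54.9% in a functional assay on CHO cells for agonist activity at Free fatty acid receptor 1 (Homo sapiens), read by FLIPR, tested at 100 nM; a lower number here means a weaker effect, a higher number a stronger effect of the compound at the concentration tested
compound 2, `Cc1cccc(NC(=O)C(=O)Nc2ccc(OCC(=O)O)c(F)c2)c1`, gives 17.7%

Compound 2 stands lowest of the two numbers in this assay; compound 1 gives a value higher by a margin beyond the usual scatter. Compound 3, `COc1ccccc1NC(=O)C(=O)Nc1ccc(OCC(=O)O)c(F)c1`, has not yet been measured; it differs from compound 2 by 2-methoxyphenyl in place of 3-methylphenyl on an amide-type nitrogen. Within the data shown here, no step between measured compounds is available to anchor the expectation. Compound 3 is expected to show a step of a number 1.7 percentage points lower from compound 2 to compound 3 (within the scatter), lying within the scatter rather than beyond it. Compound 3 is therefore estimated at 16%, within 4% to 34%.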

Compound 3, a percentage reported as activity, at one concentration (the size of the read-out at that concentration, not a potency): 6.78%
Estimate against measurement, compound 3: 9.2 percentage points above; low and high end bracket the measured number.
By their numbers in this assay, from the lowest: compound 3; then compound 2; then compound 1.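

In this assay, the group on the amide-type nitrogen turns out not to be neutral: 2-methoxyphenyl in place of 3-methylphenyl comes out as a number 10.9 percentage points lower from compound 2 to compound 3 (beyond the scatter). Among these compounds, this is the first one-place change, and it shows that the already weak read-out of this oxalamide-type pair can fall further, though the step is modest. Nothing measured here accounts for the step.

On these data alone, whether the fall follows the added oxygen or where the substituent sits on the ring stays open. As far as these compounds go, what an amine or a carboxylic acid on that ring would give is also open.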